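Phenyl to methyl on two cores, one kinase read-out

This account rests on a few compounds, and the source may have more. Where it says the series, first, only, none or still open, it means among the compounds named here.

Measured so far in an assay on isolated protein for inhibition of RAC-alpha serine/threonine-protein kinase (Homo sapiens), read by mobility shift assay, tested at 30 uM; a lower number here means less inhibition, a higher number more inhibition at the concentration tested (going by the name of the read-out):
Compound 1 `COCCNc1nc(C)cc2c1c(N)nn2C` gives 6%.
Compound 2 `COCCNc1nc(-c2ccccc2)cc2c1c(N)nn2C` gives 8%.
Compound 3 `Cc1cc2nc(-c3ccccc3)nc(N)c2c(=O)[nH]1` gives 7%.

All three numbers are low, and the values of compound 1, compound 2 and compound 3 lie within the scatter of one another, so no order among them can be read. Compound 2 and compound 1 differ by methyl in place of phenyl on an aromatic carbon, and that change gave a number 2 percentage points lower from compound 2 to compound 1 (within the scatter). Compound 4 `Cc1nc(N)c2c(=O)[nH]c(C)cc2n1` is not yet measured; it differs from compound 3 by methyl in place of phenyl on an aromatic carbon. Among the measured compounds shown here, this is the same kind of change as the one from compound 2 to compound 1, but not the same: in compound 1 the methyl sits next to the ring nitrogen, meta to a (2-methoxyethyl)amino group, on a ring with one nitrogen, whereas in compound 4 it sits between two ring nitrogen atoms, meta to an amino group, on a ring with two nitrogen. The difference between the two cores of compound 2 and compound 3 is not broken down here. Since the earlier step was a number 2 percentage points lower from compound 2 to compound 1 (within the scatter), compound 3 to compound 4 is expected to give no change at the digits printed from compound 3 to compound 4 (within the scatter). Compound 4 is therefore estimated at 7%, within 0% to 16%.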

Compound 4, a percentage reported as inhibition, at one concentration (the size of the read-out at that concentration, not a potency): -2%
The estimate for compound 4 lay 9 percentage points above the measured number; measured number below the stated range.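

In this assay, among the compounds shown here, putting methyl in place of phenyl on the aromatic carbon between two ring nitrogen atoms gave a number 9 percentage points lower from compound 3 to compound 4 (within the scatter), so on this core too the change produced no step that can be told from the scatter. Set beside the earlier step on the other core, the new step does not differ from it: the same change on two cores in this assay, a number 2 percentage points lower (within the scatter) from compound 2 to compound 1 and a number 9 percentage points lower (within the scatter) from compound 3 to compound 4, 7 percentage points apart, within the scatter of two such steps. This supports only the limited reading that the change left the number within the scatter on both cores; it does not show that the step has a fixed size from one core to another, or that methyl or phenyl gives more inhibition on either core, and all four numbers are low.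

The compounds shown carry only phenyl or methyl at this place, so it remains open whether an amine, a carboxylic acid or a longer alkyl chain there would give a number clear of the scatter on either core. As far as these compounds go, it also remains open how the same change would read on a compound with a much higher number in this assay.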